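Isobutyl on the chain carbon of compound 2

The compounds below may be only part of what the source reports. "The series", "measured", "known", "first", "only" and "open" are said of these compounds alone.

Among the measured compounds shown here, compound 2 `CCCCCCCCCC(NC(=O)CNC(=O)OCc1ccccc1)C(=O)NCc1ccc(OC)cc1` is the only compound here with a number: in an ADME assay on NIH3T3 cells (Mus musculus) for cytotoxicity, read by crystal violet staining (a higher number here means a weaker inhibitor, a lower number a stronger inhibitor), compound 2 gives 55000 nM. Compound 1 `COc1ccc(CNC(=O)C(CCCCCNC(=O)OC(C)(C)C)NC(=O)CNC(=O)OCc2ccccc2)cc1` has in this assay only a limit, > 100000 nM. For the measured compounds named here, the step of an at least 1.8-fold lower number from compound 1 to compound 2 (0.25 log units; that floor lies within the scatter) is therefore the one measured step, and it runs up against the limit of > 100000 nM in this assay, at which 1 of the 2 values shown sits, at a different place on the chain. Compound 3 `CCCCCCCCCC(NC(=O)[C@H](CC(C)C)NC(=O)OCc1ccccc1)C(=O)NCc1ccc(OC)cc1` differs from compound 2 by isobutyl in place of hydrogen on a saturated chain carbon bound to an amide-type nitrogen and a carbonyl carbon. Going by the values given here, no measured step touches that carbon, and the single step of an at least 1.8-fold lower number from compound 1 to compound 2 (0.25 log units; that floor lies within the scatter) cannot be carried over to it, so in this assay no shift beyond the scatter is expected. The expected step of no change at the digits printed from compound 2 to compound 3 (within the scatter) is accordingly close to nil. Compound 3 is estimated at 55000 nM, with a range from 18000 nM to 160000 nM, and a fair chance that only a limit is reported.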

Compound 3, half-maximal inhibitory concentration: > 200000 nM
Compound 3: no number, only a limit; the forecaster's own chance of this, stated with the estimate: 35%; middle value at least 3.6-fold (0.56 log units) from the limit.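

Until now, nothing measured had touched the saturated chain carbon bound to an amide-type nitrogen and a carbonyl carbon. In this assay, isobutyl in place of hydrogen at this carbon gives an at least 3.6-fold higher number from compound 2 to compound 3 (0.56 log units; beyond the scatter) and so makes the inhibitor weaker, which shows that the read-out responds to a change in this place. Only the lowest possible size of this step is known, because compound 3 gives a limit of the assay and not a number: the limit of > 200000 nM in this assay, at which 1 of the 3 values shown sits.

The compounds shown leave open how large the step really is and whether a smaller group, such as methyl, would shift the read-out at this carbon as well. Going by these compounds, what an amine or a carboxylic acid in the same place would do also remains open.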